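The compounds below may be only part of what the source reports. "The series", "measured", "known", "first", "only" and "open" are said of these compounds alone.

The compounds here were tested in a functional assay (aorta) with Oryctolagus cuniculus as the target; on this read-out higher numbers stand for weaker inhibition and lower numbers for stronger inhibition. Compound 1, with the structure `OCc1ccc(-c2nn(Cc3ccccc3F)c3ccccc23)o1`, gives 4900 nM; 4900 nM (2 entries) in this assay. Compound 2, with the structure `OCc1ccc(-c2nn(Cc3cccc(F)c3)c3ccccc23)o1`, gives 10000 nM. Compound 3, with the structure `CCCCCCc1cnc(-c2nn(Cc3ccccc3F)c3ncccc23)nc1N`, gives 1040000 nM, the highest of the two single numbers shown; the gap between compound 3 and compound 2 lies far beyond the scatter of repeated measurements.

Compound 4, with the structure `NCc1cnc(-c2nn(Cc3ccccc3F)c3ncccc23)nc1N`, has not yet been measured. It differs from compound 3 in one place: amino in place of pentyl on a saturated chain carbon bound to an aromatic carbon. The pentyl that leaves carries no hydrogen-bond donors or acceptors, whereas the amino that enters brings one donor and one acceptor, on a saturated chain carbon bound to an aromatic carbon.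

For the measured compounds named here, no pair of measured compounds differing in a single place is available, so there is no measured step to lean on, and the change is judged from the structures alone. The expected step from compound 3 to compound 4 is estimated at a 2.1-fold lower number from compound 3 to compound 4 (0.32 log units; beyond the scatter), toward stronger inhibition, though it may not exceed the scatter. Compound 4 is accordingly expected to give 500000 nM, within a range from 100000 nM to 3000000 nM.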

Compound 4, half-maximal inhibitory concentration: 1400000 nM
Compound 4: the middle estimate sits 2.8-fold (0.45 log units) below what was measured; measured number inside the range.
By their numbers in this assay, from the lowest: compound 2; then compounds 3 and 4 (each within the scatter of the next).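

For the compounds shown here, this is the first step where only one place changes, and in this assay it shows no readable effect: a 1.3-fold higher number from compound 3 to compound 4 (0.13 log units; within the scatter). On a saturated chain carbon bound to an aromatic carbon, replacing pentyl with amino, which can also be read as hexyl to aminomethyl, removes a hydrocarbon chain and adds a hydrogen-bond donor and acceptor, yet the two numbers cannot be told apart. No further data accompany this pair, so the result stands without any explanation of why the number holds.

A single step cannot show whether this place is insensitive to all changes or only to this one, and a group such as a carboxylic acid, a hydroxyl or a longer chain ending in an amine might still move the number beyond the scatter. Going by these compounds, it also remains open whether the same swap would leave the number unchanged on a different core, such as that of compound 1, where the starting number is much lower and a change may be easier to detect.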